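Stripping the amide substituent from compound 3

A few compounds are considered here, and "the series" means these few. Any claim that something is new, unique, unknown or untested is made for them only; others in the source may bear on it.

In a functional assay (muscle tissue) with Rattus norvegicus as the target (a higher number here means that more compound is needed for the effect, a lower number that less compound is needed), compound 1 (`CCCNC(=O)C1=CC(C)(C)Oc2ccc([N+](=O)[O-])cc21`) gives 5.75 nM and compound 2 (`CC1(C)C=C(C(=O)NC2CC2)c2cc([N+](=O)[O-])ccc2O1`) gives 32.4 nM, while compound 3 (`CC1(C)C=C(C(=O)NCCO)c2cc([N+](=O)[O-])ccc2O1`) gives 182 nM as the highest number of the three. Compound 4 (`CC1(C)C=C(C(N)=O)c2cc([N+](=O)[O-])ccc2O1`) carries hydrogen in place of 2-hydroxyethyl on an amide-type nitrogen. The measured steps at this nitrogen are a 5.6-fold higher number from compound 1 to compound 2 (0.75 log units; beyond the scatter) and a 5.6-fold higher number from compound 2 to compound 3 (0.75 log units; beyond the scatter) and also a 32-fold higher number from compound 1 to compound 3 (1.50 log units; beyond the scatter) and all lie beyond the scatter. Among the measured compounds shown here, no measured compound has hydrogen there, so the direction remains uncertain. Going by the size of a 5.6-fold higher number from compound 2 to compound 3 (0.75 log units; beyond the scatter) as a guide, the expected change is a 1.9-fold higher number from compound 3 to compound 4 (0.28 log units; within the scatter) in this assay as a modest rise. Compound 4 is estimated at 350 nM with a range from 90 nM to 1500 nM in this estimate.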

Compound 4, half-maximal effective concentration: 363 nM
Compound 4: middle estimate off by 1.0-fold (0.02 log units), on the low side; low and high end bracket the measured number.
By their numbers in this assay, from the lowest: compound 1; then compound 2; then compounds 3 and 4 (each within the scatter of the next).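

In this assay hydrogen in place of 2-hydroxyethyl on the amide-type nitrogen gives a 2.0-fold higher number from compound 3 to compound 4 (0.30 log units; within the scatter) and so does not separate these two compounds. Hydrogen in place of cyclopropyl gives an 11-fold higher number from compound 2 to compound 4 (1.05 log units; beyond the scatter) and hydrogen in place of propyl gives a 63-fold higher number from compound 1 to compound 4 (1.80 log units; beyond the scatter) so among these four compounds propyl and cyclopropyl are the substituents that stand apart from hydrogen. No measurement at hand bears on the reason for this. As far as these compounds go, whether a longer chain such as butyl would sit with propyl or with hydrogen stays open. So does the place of a 2-aminoethyl or carboxymethyl group on this nitrogen.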